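The compounds below may be only part of what the source reports. "The series", "measured", "known", "first", "only" and "open" are said of these compounds alone.

Compound 2 `CCCOCC(=O)Nc1cc2nc(C3CCCCC3)[nH]c2cc1N(C)C` carries a propoxymethyl group on a carbonyl carbon. In an ADME assay on Vero cells (Chlorocebus sabaeus) for cytotoxicity, read by resazurin assay, with a stated time of 3 days (on this read-out lower numbers stand for stronger inhibition and higher numbers for weaker inhibition), compound 2 gives < 50 ug/mL, which is a limit of the assay rather than a number. Compound 1 `Cc1ccc(C(=O)Nc2cc3nc(C4CCCCC4)[nH]c3cc2N(C)C)cc1` carries 4-methylphenyl at that carbonyl carbon instead. In this assay compound 1 gives > 100 ug/mL, also a limit. Among the compounds with values here, the only measured step, an at least 2.0-fold lower number from compound 1 to compound 2 (0.30 log units; that floor lies within the scatter), runs toward lower numbers with propoxymethyl in place of 4-methylphenyl. Compound 3 `CN(C)c1cc2[nH]c(C3CCCCC3)nc2cc1NC(=O)c1ccc(F)cc1` goes back the other way: 4-fluorophenyl in place of propoxymethyl on a carbonyl carbon. A higher number is therefore expected for compound 3, an at least 2.0-fold higher number from compound 2 to compound 3 (0.30 log units; that floor lies within the scatter). The value estimated for compound 3 is 100 ug/mL, ranging from 45 ug/mL to 220 ug/mL, and quite possibly only a limit again.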

Compound 3, half-maximal inhibitory concentration: > 100 ug/mL
Compound 3 gave a limit, no number; the forecaster's own chance of this, stated with the estimate: 70%; the middle value lies on the limit itself.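

In this assay, a second phenyl group on the carbonyl carbon, 4-fluorophenyl, now stands against propoxymethyl, giving an at least 2.0-fold higher number from compound 2 to compound 3 (0.30 log units; that floor lies within the scatter). Both compounds with a substituted phenyl group there thus sit at one limit, while the propoxymethyl compound sits at the other: the limit of > 100 ug/mL in this assay, at which 2 of the 3 values shown sit. The change from compound 1 to compound 3, fluoro in place of methyl, cannot be read, as both values are limits. Going by these compounds, the true size of each step stays open, since limits are not numbers. Also open, on these data alone, is where an amine or a longer chain on that carbonyl carbon would fall.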